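The source may report more compounds than this note shows. Statements on the series, on what has been measured and on what is new or still open speak of the compounds shown alone.

Compound 1 `Oc1ccc(O)c(COCc2cc(O)cc(Cl)c2O)c1`, compound 2 `Oc1ccc(O)c(COCc2cc(O)ccc2O)c1` and compound 3 `COCc1cc(O)cc(Cl)c1O` have been measured in a functional assay; a lower number here means a stronger inhibitor, a higher number a weaker inhibitor. In this assay compound 1 gives 4300 nM and compound 2 gives 4600 nM; the change between them is hydrogen in place of chloro on an aromatic carbon, and the step was a 1.1-fold higher number from compound 1 to compound 2 (0.03 log units; within the scatter). Compound 3 gives 8500 nM in this assay. The difference between the core of compound 3 and the core of compound 1 is not broken down here. Compound 4 `COCc1cc(O)ccc1O` has not yet been measured; it differs from compound 3 by hydrogen in place of chloro on an aromatic carbon. This is the same kind of change as that from compound 1 to compound 2, though the place differs: there the site was meta to a large group, here meta to a methoxymethyl group. Beside the earlier step, the step expected in this assay is a 1.1-fold higher number from compound 3 to compound 4 (0.02 log units; within the scatter), resting on the near-unchanged result of compound 1 to compound 2 a 1.1-fold higher number from compound 1 to compound 2 (0.03 log units; within the scatter). Compound 4 is therefore estimated at 9000 nM, between 4500 nM and 18000 nM.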

Compound 4, half-maximal inhibitory concentration: 9800 nM
Estimate against measurement, compound 4: 1.1-fold (0.04 log units) below, and the stated range covers the measured number.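

In this assay, hydrogen in place of chloro gave a 1.2-fold higher number from compound 3 to compound 4 (0.06 log units; within the scatter). Set beside the earlier step, the same change gives results on the two cores that cannot be told apart: the same change on two cores in this assay, a 1.1-fold higher number (0.03 log units; within the scatter) from compound 1 to compound 2 and a 1.2-fold higher number (0.06 log units; within the scatter) from compound 3 to compound 4, 1.1-fold (0.03 log units) apart, within the scatter of two such steps. This shows that the exchange of chloro for hydrogen can be carried between these two cores with no step beyond the scatter, but it gives no effect of measurable size to carry over and says nothing about other cores or other places on the ring.

The compounds shown leave open whether a group other than chloro at this place, such as a methoxy group, an amine or a carboxylic acid, would shift the number. They also leave open what a longer chain in place of the methoxymethyl group would do.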